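The compounds below may be only part of what the source reports. "The series", "measured", "known", "first", "only" and "open" are said of these compounds alone.

Compound 1 `CC(C)=CCC1Cc2c(O)cc(=O)n(CCCO)c2CC1(C)C` in a functional assay on PANC-1 cells (Homo sapiens) for inhibition, read by MTT assay, with a stated time of 24 h, tested at 10 uM (on this read-out higher numbers stand for more inhibition at the one concentration tested (going by the name of the read-out) and lower numbers for less inhibition), gives 25.6%. Among the compounds with values here, compound 2 `CC(C)=CCC1Cc2c(OC(=O)Nc3ccc(F)cc3F)cc(=O)n(CCCO)c2CC1(C)C` gives 69.7% in this assay, the higher of the two numbers, with a number 44.1 percentage points higher from compound 1 to compound 2 (beyond the scatter) the only step measured so far. Compound 3 `CC(C)=CCC1Cc2c(OC(=O)Nc3ccc(F)c(F)c3)cc(=O)n(CCCO)c2CC1(C)C` differs from compound 2 by 3,4-difluorophenyl in place of 2,4-difluorophenyl on an amide-type nitrogen. Within the data shown here, no measured step touches the substitution pattern of the difluorophenyl group, so the large step from compound 1 to compound 2 does not bear on this change; no step beyond the scatter is expected in this assay, with a number 4.7 percentage points lower from compound 2 to compound 3 (within the scatter) as the expected shift. Compound 3 is estimated at 65%, within 45% to 85%.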

Compound 3, a percentage reported as inhibition, at one concentration (the size of the read-out at that concentration, not a potency): 76.7%
Compound 3: the middle estimate sits 11.7 percentage points below what was measured; the range from low to high includes it.
By their numbers in this assay, from the lowest: compound 1; then compounds 2 and 3 (each within the scatter of the next).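

In this assay, 3,4-difluorophenyl in place of 2,4-difluorophenyl on the amide-type nitrogen gives a number 7 percentage points higher from compound 2 to compound 3 (within the scatter), so this change of fluorine pattern is not resolved by this read-out. The gain over the core of compound 1 is not confined to one pattern: (3,4-difluorophenyl)carbamoyl in place of hydrogen on the oxygen gives a number 51.1 percentage points higher from compound 1 to compound 3 (beyond the scatter) as well. No evidence is available on what lies behind these numbers.

Open, going by these compounds, is whether the fluorines matter at all, which an unsubstituted phenyl would test. On these data alone, whether an aromatic ring is needed on this nitrogen also remains open, which a cyclohexyl or a butyl chain would test.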